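This account rests on a few compounds, and the source may have more. Where it says the series, first, only, none or still open, it means among the compounds named here.

Three compounds share one core and differ only in the branched chain attached to a double-bonded nitrogen. In a functional assay on the whole organism (blood, strain Wistar-Okamoto) with Rattus norvegicus as the target, with a stated time of 5 days (on this read-out lower numbers stand for an effect already at smaller amounts and higher numbers for an effect only at larger amounts of compound), compound 1 `CC(C)C/N=C(\NC#N)Nc1cccnc1` gives 20 mg/kg. Compound 2 `CCC(C)/N=C(\NC#N)Nc1cccnc1` gives 20 mg/kg in this assay, and compound 3 `CCC(CC)/N=C(\NC#N)Nc1cccnc1` gives 20 mg/kg. Taken together, no change at the digits printed from compound 1 to compound 2 (within the scatter), no change at the digits printed from compound 1 to compound 3 (within the scatter) and no change at the digits printed from compound 2 to compound 3 (within the scatter) show that swapping one branched chain for another has so far left the read-out where it was, and compound 3 stands level with compounds 1 and 2.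

Compound 4 `CC(C)C(C)(C)/N=C(\NC#N)Nc1cccnc1` carries the next change of this kind: 1,1,2-trimethylpropyl in place of pentan-3-yl on a double-bonded nitrogen. The two steps that end at compound 3, no change at the digits printed from compound 1 to compound 3 (within the scatter) and no change at the digits printed from compound 2 to compound 3 (within the scatter), bear on it most directly, and both stayed within the scatter, as did no change at the digits printed from compound 1 to compound 2 (within the scatter). A further swap of one branched chain for another is therefore expected to bring no movement beyond the scatter, no change at the digits printed from compound 3 to compound 4 (within the scatter). Compound 4 is expected to give 20 mg/kg in this assay, within a range from 10 mg/kg to 40 mg/kg.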

Compound 4, minimum effective dose: 1 mg/kg
Beside the measured number, compound 4's estimate is 20-fold (1.30 log units) above it; measured number outside the range, below it.
By their numbers in this assay, from the lowest: compound 4; then compounds 1, 2 and 3 (each within the scatter of the next).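

In this assay this position on a double-bonded nitrogen proves not to be indifferent to the chain it carries: 1,1,2-trimethylpropyl gives a 20-fold lower number from compound 3 to compound 4 (1.30 log units; beyond the scatter) and likewise a 20-fold lower number from compound 2 to compound 4 (1.30 log units; beyond the scatter) and a 20-fold lower number from compound 1 to compound 4 (1.30 log units; beyond the scatter) in place of the earlier branched chains. Swapping among isobutyl, sec-butyl and pentan-3-yl had shown no such movement, so the earlier flat stretch says little about this position as a whole, and compound 4 now has the lowest number of the four. Nothing measured here explains why this one change has so large an effect.

The compounds shown leave open which of the methyl branches of 1,1,2-trimethylpropyl the step depends on. They also leave open how a cyclohexyl ring, a longer straight chain or a chain ending in an amine would read out at this place.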